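A few compounds are considered here, and "the series" means these few. Any claim that something is new, unique, unknown or untested is made for them only; others in the source may bear on it.

Working notes on the series, values from a functional assay on HeLa cells (Homo sapiens) for antiproliferative activity, read by MTT assay, with a stated time of 72 h; a higher number here means a weaker inhibitor, a lower number a stronger inhibitor:

- compound 1 `COc1ncc(-c2ccc3c(c2)NC(=O)CO3)cc1NS(=O)(=O)c1ccc(F)cc1` gives 7110 nM
- compound 2 `COc1ccc(N2C(=O)COc3ccc(-c4cnc(Cl)c(NS(=O)(=O)c5ccc(F)cc5)c4)cc32)cc1` gives 8320 nM
- compound 3 `COc1ncc(-c2ccc3c(c2)N(C2CCCCC2)C(=O)CO3)cc1NS(=O)(=O)c1ccc(F)cc1` gives 6100 nM

Compound 2 at 8320 nM lies within the scatter of both compound 1 and compound 3, so the three values do not separate.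

Next is compound 4 `O=C1COc2ccc(-c3cnc(Cl)c(NS(=O)(=O)c4ccc(F)cc4)c3)cc2N1c1ccc(F)cc1`, not yet measured. It differs from compound 2 as follows: fluoro in place of methoxy on an aromatic carbon. In words, this is fluoro in place of methoxy on an aromatic carbon, 4-methoxyphenyl to 4-fluorophenyl.

Among the compounds with values here, no measured step tests this exchange directly. Within the data shown here, the only measured step, a 1.2-fold lower number from compound 1 to compound 3 (0.07 log units; within the scatter), is a different change, cyclohexyl in place of hydrogen on an amide-type nitrogen in a ring. It stays within the scatter and offers only weak guidance, showing little movement in this series.

No step beyond the scatter is therefore expected, in either direction. The estimated step is a 1.1-fold lower number from compound 2 to compound 4 (0.05 log units; within the scatter). For compound 4 the expected value is 7500 nM, with an estimated range of 3500 nM to 15000 nM.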

Compound 4, half-maximal inhibitory concentration: > 40000 nM
Compound 4: no number, only a limit; the forecaster's own chance of this, stated with the estimate: 10%; middle value at least 5.3-fold (0.72 log units) away from the limit.
By their numbers in this assay, from the lowest: compounds 3, 1 and 2 (each within the scatter of the next). At a limit, above all of these: compound 4.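

In this assay compound 4 gives > 40000 nM, which is a limit of the assay and not a number: the limit of > 40000 nM in this assay, at which 1 of the 4 values shown sits.

Within the data shown here, with an at least 4.8-fold higher number from compound 2 to compound 4 (0.68 log units; beyond the scatter), this is the first step that lies beyond the scatter, so the group on this aromatic carbon, para to a large group, does affect the read-out. An exchange as small as methoxy to fluoro is enough here, whereas the cyclohexyl exchange in a 1.2-fold lower number from compound 1 to compound 3 (0.07 log units; within the scatter) stayed within the scatter.

The limit leaves the full size of the step open, and two groups at this place cannot show whether methoxy is specifically favoured or fluoro specifically disfavoured. An amine, a hydroxyl or a longer alkoxy chain such as ethoxy at the same place would help separate these two readings.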